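The source may hold more compounds than are shown below. What is called first, only, known or untested is meant among the compounds shown, and "the series" means these compounds.

Compound 1 `Cc1ccccc1-n1nc(C)c2c1NC(=O)[C@H](C)S[C@@H]2c1ccc(Oc2ccccc2C(=O)O)cc1` was tested in an assay on isolated protein for agonist activity at Bile acid receptor (Homo sapiens), read by AlphaScreen, with a stated time of 30 min (on this read-out lower numbers stand for an effect already at smaller amounts and higher numbers for an effect only at larger amounts of compound), and gave "not active" (no number reported), so there is no number to fix where it stands on that scale. Another compound, compound 2 `Cc1ccc(-n2nc(C)c3c2NC(=O)[C@H](C)S[C@@H]3c2ccc(Oc3ccccc3)cc2)cc1`, was tested as well, and in this assay compound 2 gives 3400 nM. Compound 3 `COc1ccc(Oc2ccc([C@H]3S[C@@H](C)C(=O)Nc4c3c(C)nn4-c3ccccc3C)cc2)cc1` has not been measured yet. It differs from compound 1 in a single place: 4-methoxyphenyl in place of 2-carboxyphenyl on an oxygen on an aromatic ring. Going by the values given here, no measured pair here shows this exact change, so the size of the step cannot be read from the data. The expectation for compound 3 therefore rests on compound 2, whose 3400 nM shows that this shared core can produce a measurable effect, while compound 1 offers no number at all. A step from no reported activity to a measurable value is expected, in the direction of an effect at smaller amounts. Compound 3 is expected to come in near 3000 nM, within a range from 800 nM to 15000 nM.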

Compound 3, half-maximal effective concentration: 2200 nM
For compound 3 the middle estimate is 1.4-fold (0.13 log units) above the measured one; the measured number falls inside the stated range.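

No step can be read between compound 1 and compound 3, as compound 1 has no number on this scale. The compounds shown leave open how large the effect of exchanging 2-carboxyphenyl for 4-methoxyphenyl is. No measured evidence bears on the cause of this result.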